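Carboxy to methoxy on the aryl amide of compound 2

This account rests on a few compounds, and the source may have more. Where it says the series, first, only, none or still open, it means among the compounds named here.

Measured so far in an assay on isolated protein for inhibition of Apoptosis regulator Bcl-2 (Homo sapiens), read by fluorescence polarization, with stated times of 5 min and 10 min; on this read-out lower numbers stand for stronger inhibition and higher numbers for weaker inhibition:
compound 1 `CC(C)=CCCC1=CC[C@H](C(=O)NO)[C@@H](c2ccccc2)C1`, 600 nM
compound 2 `CC(C)=CCCC1=CC[C@@H](C(=O)Nc2ccc(C(=O)O)cc2)[C@H](c2ccccc2)C1`, 2200 nM
compound 3 `CC(C)=CCCC1=CC[C@H](C(=O)Nc2ccc(C(=O)O)cc2)[C@@H](c2ccccc2)C1`, > 23000 nM

Compound 3 returns only a limit in this assay, (the limit of > 23000 nM in this assay, at which 1 of the 3 values shown sits). Of the two numbers, compound 2 gives the higher and compound 1 the lower. Compound 4 `COc1ccc(NC(=O)[C@@H]2CC=C(CCC=C(C)C)C[C@H]2c2ccccc2)cc1` differs from compound 2 as follows: methoxy in place of carboxy on an aromatic carbon. Going by the values given here, no measured step alters the group on the aromatic ring: an at least 38-fold higher number from compound 1 to compound 3 (1.58 log units; beyond the scatter) swaps hydroxy for 4-carboxyphenyl, and an at least 10-fold higher number from compound 2 to compound 3 (1.01 log units; beyond the scatter) rests on (the fact that compounds 2 and 3 differ only in the configuration as drawn). Both are large but neither speaks to carboxy against methoxy. A step of moderate size is therefore expected, a 2.0-fold higher number from compound 2 to compound 4 (0.31 log units; beyond the scatter), leaning toward a higher number. Compound 4 is estimated at 4500 nM, between 1500 nM and 14000 nM.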

Compound 4, inhibition constant: > 23000 nM
Compound 4 gave a limit, no number; the forecaster's own chance of this, stated with the estimate: 15%; middle value at least 5.1-fold (0.70 log units) away from the limit.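

In this assay, going by these compounds alone, methoxy in place of carboxy on the aromatic carbon gives an at least 10-fold higher number from compound 2 to compound 4 (1.01 log units; beyond the scatter), the first measured step at this position, and it shows that the ring substituent matters as much as the configuration does. Compound 4 returns only a limit, > 23000 nM. The step therefore sets a bound and not a size: the limit of > 23000 nM in this assay, at which 2 of the 4 values shown sit.

On these data alone, whether a sulfonic acid, a primary amide or a hydroxymethyl group in place of carboxy would keep the number of compound 2 stays open. So does whether a hydroxy group here would do the same.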